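Cytotoxicity of Three Benzyl Ethers and an Aldehyde Analogue

A few compounds are considered here, and "the series" means these few. Any claim that something is new, unique, unknown or untested is made for them only; others in the source may bear on it.

Measured in an ADME assay on HEK293 cells (Homo sapiens) for cytotoxicity, read by CCK-8 assay, with a stated time of 48 h; a higher number here means a weaker inhibitor, a lower number a stronger inhibitor:
Compound 1, `COc1ccc(/C=C\c2cc(OC)c(OC)c(OC)c2)cc1OCc1ccc(CN2CC(C(=O)O)C2)cc1`: a limit, > 50000 nM.
Compound 2, `COc1ccc(/C=C\c2cc(OC)c(OC)c(OC)c2)cc1OCc1ccc(CN2CCCC[C@H]2C(=O)O)cc1`: a limit, > 50000 nM.
Compound 3, `COc1ccc(/C=C\c2cc(OC)c(OC)c(OC)c2)cc1OCc1ccc(CN2CC[C@H](O)C2)cc1`: a limit, > 50000 nM.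

Compound 1 stands at the limit of > 50000 nM in this assay, at which 3 of the 3 values shown sit, so its own position is known only as that limit. Compound 4, `COc1ccc(/C=C\c2cc(OC)c(OC)c(OC)c2)cc1OCc1ccc(C=O)cc1`, differs from it in one place: formyl in place of (3-carboxyazetidin-1-yl)methyl on an aromatic carbon. The measured steps that might bear on this are a step that the two limits leave unreadable from compound 1 to compound 2, a step that the two limits leave unreadable from compound 1 to compound 3 and a step that the two limits leave unreadable from compound 2 to compound 3; each exchanges the ring-bearing group on the saturated chain carbon rather than removing it, and each is unreadable, so none supplies a size or a direction to carry over. Compound 4 is therefore expected to stay weak in this assay, with an estimated step of an at least 1.2-fold lower number from compound 1 to compound 4 (0.09 log units; that floor lies within the scatter), and with a real chance that only a limit is again reported. The estimate for compound 4 is 40000 nM, expected to fall between 10000 nM and 100000 nM.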

Compound 4, half-maximal inhibitory concentration: 46000 nM
Estimate against measurement, compound 4: 1.2-fold (0.06 log units) below; low and high end bracket the measured number.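

In this assay, for the compounds shown here, compound 4 gives a measured number, 46000 nM, where the earlier compounds gave none. Formyl on this aromatic carbon, in place of each ring-bearing methyl group, yields an at least 1.0-fold lower number from compound 1 to compound 4 (0.03 log units; that floor lies within the scatter), an at least 1.0-fold lower number from compound 3 to compound 4 (0.03 log units; that floor lies within the scatter) and an at least 1.0-fold lower number from compound 2 to compound 4 (0.03 log units; that floor lies within the scatter), so the loss of the saturated ring shows no change beyond the scatter. Compound 1, compound 2 and compound 3 each remain a limit: the limit of > 50000 nM in this assay, at which 3 of the 4 values shown sit.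

From the compounds shown here alone, the steps among compound 1, compound 2 and compound 3 cannot be read, so their order stays open. Also open, going by these compounds, is what a carboxylic acid or a primary amine set directly on this aromatic carbon would give.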